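A few compounds are considered here, and "the series" means these few. Any claim that something is new, unique, unknown or untested is made for them only; others in the source may bear on it.

Compound 3, `Cc1ccc(S(=O)(=O)NCc2ccc(CNC(=O)c3ccccc3C)cc2)cc1`, is one of three close analogues that share a core and differ only in the aryl group on the carbonyl carbon of the amide. In an assay on MDA-MB-231 cells for binding affinity to C-X-C chemokine receptor type 4 (Homo sapiens), read by immunofluorescence and microscopy, with stated times of 10 min and 30 min (on this read-out lower numbers stand for an effect already at smaller amounts and higher numbers for an effect only at larger amounts of compound), compound 3 gives 100 nM. Compound 1, `COc1ccc(C(=O)NCc2ccc(CNS(=O)(=O)c3ccc(C)cc3)cc2)cc1`, gives 100 nM in this assay, and the two stand level, with no change at the digits printed from compound 1 to compound 3 (within the scatter). Compound 2, `Cc1ccc(S(=O)(=O)NCc2ccc(CNC(=O)c3cccc(F)c3)cc2)cc1`, gives 1 nM, the lowest of the three numbers; the step from it to compound 3 is large, a 100-fold higher number from compound 2 to compound 3 (2.00 log units; beyond the scatter), and the step from compound 1 to compound 2 is equally large, a 100-fold lower number from compound 1 to compound 2 (2.00 log units; beyond the scatter).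

Compound 4, `Cc1ccc(S(=O)(=O)NCc2ccc(CNC(=O)c3cccc(C)c3)cc2)cc1`, carries the change (3-methylphenyl in place of 2-methylphenyl on a carbonyl carbon). The bearing steps are the two large ones: a 3-fluorophenyl gave the low number of compound 2, while the 2-methylphenyl of compound 3 and the 4-methoxyphenyl of compound 1 both gave the high number. Compound 4 carries a 3-methylphenyl, as compound 2 carries a 3-fluorophenyl, so a step toward a lower number is expected, though methyl is not fluorine and the size is uncertain. Compound 4 is therefore estimated at 10 nM, within 1 nM to 100 nM, an expected step of a 10-fold lower number from compound 3 to compound 4 (1.00 log units; beyond the scatter).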

Compound 4, effective concentration (reported as EC, without a stated level of effect): 1000 nM
Compound 4: the middle estimate sits 100-fold (2.00 log units) below what was measured; the measured number lies above the stated range.
By their numbers in this assay, from the lowest: compound 2; then compounds 1 and 3 (each within the scatter of the next); then compound 4.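

Moving the methyl from the 2-methylphenyl to the 3-methylphenyl on the carbonyl carbon, with the same atoms joined differently, gives a 10-fold higher number from compound 3 to compound 4 (1.00 log units; beyond the scatter) and shows that the number in this assay depends on where the methyl sits on this ring. Methyl in place of fluoro on an aromatic carbon gives a 1000-fold higher number from compound 2 to compound 4 (3.00 log units; beyond the scatter) and is the widest step in the set, so the low number of compound 2 belongs to the 3-fluorophenyl and does not carry over to the 3-methylphenyl, while the change from the 4-methoxyphenyl gives a 10-fold higher number from compound 1 to compound 4 (1.00 log units; beyond the scatter) as well. Nothing in the data shown accounts for these steps.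

The compounds shown leave open where a 3-chlorophenyl or a 3-cyanophenyl would stand relative to the 3-fluorophenyl and the 3-methylphenyl. They also leave open what a 2-fluorophenyl or a 4-fluorophenyl would give on the same carbonyl carbon.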